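A few compounds are considered here, and "the series" means these few. Any claim that something is new, unique, unknown or untested is made for them only; others in the source may bear on it.

Measured so far in a functional assay on PC-12 cells (Rattus norvegicus) for inhibition, read by sulforhodamine B assay; on this read-out higher numbers stand for weaker inhibition and lower numbers for stronger inhibition:
- compound 1 `CCOc1ccc(CC2SC(=O)NC2=O)cc1`: > 100000 nM
- compound 2 `COc1ccc(CC2SC(=O)NC2=O)cc1`: > 100000 nM

Compound 2 gives > 100000 nM, which is a limit of the assay and not a number. Compound 1 gives > 100000 nM, which is also a limit. Going by the values given here, the series so far therefore sits at one place, (the limit of > 100000 nM in this assay, at which 2 of the 2 values shown sit).

The next change leads to compound 3 `O=C1NC(=O)C(Cc2ccccc2)S1`: hydrogen in place of methoxy on an aromatic carbon, with hydrogen in place of methoxy on an aromatic carbon. Among the compounds with values here, the only measured step is a step that the two limits leave unreadable from compound 1 to compound 2. It alters the same substituent, shortening the saturated chain on the oxygen, but its size cannot be read and so it offers no measure to carry over. Within the data shown here, no measured compound yet lacks this substituent.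

The expectation in this assay is therefore for no step beyond the scatter and no particular direction, and it rests on compound 2 with its limit of > 100000 nM. The expected change is a number no higher from compound 2 to compound 3 (the limit leaves the size open). For compound 3 the estimate is 100000 nM, with an expected range of 40000 nM to 200000 nM.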

Compound 3, half-maximal inhibitory concentration in the PC-12 assay: > 100000 nM
Compound 3 gave a limit, no number (the forecaster's own chance of this, stated with the estimate: 85%); the middle value lies on the limit itself.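

In the PC-12 assay compound 3 gives > 100000 nM, a limit of the assay and not a number. No step among compound 1, compound 2 and compound 3 can be read, and all three stand at one place: the limit of > 100000 nM in the PC-12 assay, at which 3 of the 3 values shown sit.

The compounds shown leave open whether any change to the substituent on the shared core would give a readable number in the PC-12 assay.

In a physicochemical assay for lipophilicity (a higher number here means a more lipophilic compound, a lower number a more polar compound), compound 2 gives 1.91 and compound 3 gives 1.99. In the physicochemical assay the step is a number 0.08 log units higher from compound 2 to compound 3 (within the scatter).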